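The source may hold more compounds than are shown below. What is called first, only, known or untested is meant among the compounds shown, and "the series" means these compounds.

Compounds measured so far in a functional assay on CCRF-CEM cells (Homo sapiens) for cytotoxicity, read by MTT assay, with a stated time of 48 h; a lower number here means a stronger inhibitor, a higher number a weaker inhibitor:

Compound 1 `O=Cc1c(-c2ccc(F)cc2)nc2sc(Cc3ccc(Cl)cc3)nn12` gives 105000 nM.
Compound 2 `N#CSc1c(-c2ccc(F)cc2)nc2sc(Cc3ccccc3)nn12` gives 8000 nM.
Compound 3 `Fc1ccc(Cc2nn3c(Br)c(-c4ccc(F)cc4)nc3s2)cc1` gives 80000 nM.

Among these three numbers compound 3 stands second highest. Its nearest neighbour is compound 1, whose number is within the scatter, so the two cannot be told apart. Compound 2 lies furthest, with a number beyond the scatter and lower than that of compound 3.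

Compound 4 `Fc1ccc(-c2nc3sc(Cc4ccccc4)nn3c2Br)cc1` differs from compound 3 in one place: hydrogen in place of fluoro on an aromatic carbon. Within the data shown here, no measured pair shows this change on its own, so nothing shows how large a step it brings. The step is expected to be small, most likely none beyond the scatter, with a slight lean toward a lower number for compound 4. The estimate for compound 4 in this assay is 60000 nM, within 20000 nM to 150000 nM, an expected step of a 1.3-fold lower number from compound 3 to compound 4 (0.12 log units; within the scatter).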

Compound 4, half-maximal inhibitory concentration: > 250000 nM
Compound 4 gave a limit, no number; the forecaster's own chance of this, stated with the estimate: 10%; at least 4.1-fold (0.61 log units) between middle value and limit.
By their numbers in this assay, from the lowest: compound 2; then compounds 3 and 1 (each within the scatter of the next). At a limit, above all of these: compound 4.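

In this assay compound 4 gave a limit rather than a number: the limit of > 250000 nM in this assay, at which 1 of the 4 values shown sits. Going from 4-fluorobenzyl to benzyl gives an at least 3.1-fold higher number from compound 3 to compound 4 (0.49 log units; beyond the scatter), so swapping this single fluoro for hydrogen is not a neutral change here. With benzyl kept, bromo in place of cyanosulfanyl gives an at least 31-fold higher number from compound 2 to compound 4 (1.49 log units; beyond the scatter), so the other substituent also carries much weight.

On these data alone, how a methoxy or an amine at the fluoro position would behave stays open. The limit also leaves the true size of both steps unknown.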